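The source may report more compounds than this note shows. Statements on the series, on what has been measured and on what is new or still open speak of the compounds shown alone.

Measured so far in an ADME assay on MT4 cells (Homo sapiens) for cytotoxicity, read by MTT assay, with a stated time of 4 days; a higher number here means that more compound is tolerated, a lower number that less compound is tolerated:
compound 1 `COc1cc(C#N)cc(OC)c1Oc1nc(Nc2ccc(C#N)cc2)nc2ccccc12`; compound 1 gives 194000 nM
compound 2 `COc1ccc(Oc2nc(Nc3ccc(C#N)cc3)nc3ccccc23)cc1`; compound 2 gives 340000 nM
compound 3 `Cc1cc(C#N)cc(C)c1Oc1nc(Nc2ccc(C#N)cc2)nc2ccccc12`; compound 3 gives 203000 nM

The three numbers lie close together. Compound 3 sits nearest to compound 1, with the gap between the two within the scatter, and the gap from compound 3 to compound 2 is also within the scatter. Nothing separates these three compounds beyond the usual variation of repeated measurements.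

Compound 4 `N#Cc1ccc(Nc2nc(Oc3ccccc3Cl)c3ccccc3n2)cc1` has not yet been measured in this assay. It differs from compound 3 at a single place: 2-chlorophenyl in place of 4-cyano-2,6-dimethylphenyl on an oxygen on an aromatic ring.

Within the data shown here, one measured step bears on this change: a 1.7-fold lower number from compound 2 to compound 3 (0.22 log units; within the scatter). That step likewise exchanged the group on the oxygen on an aromatic ring and moved the number by no more than the scatter. A further exchange of the same group is therefore expected to give no step beyond the scatter in this assay. For compound 4 the expected value is 200000 nM, with a range from 100000 nM to 400000 nM. The estimated step is a 1.0-fold lower number from compound 3 to compound 4 (0.01 log units; within the scatter), expected to stay within the scatter.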

Compound 4, half-maximal cytotoxic concentration: 38000 nM
For compound 4 the middle estimate is 5.3-fold (0.72 log units) above the measured one; measured number outside the range, below it.
By their numbers in this assay, from the lowest: compound 4; then compounds 1, 3 and 2 (each within the scatter of the next).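

In this assay the group on the oxygen on an aromatic ring can move the number: 2-chlorophenyl gives a 5.3-fold lower number from compound 3 to compound 4 (0.73 log units; beyond the scatter) and an 8.9-fold lower number from compound 2 to compound 4 (0.95 log units; beyond the scatter) in the same place. Both steps lie beyond the scatter, which the earlier exchange of a 1.7-fold lower number from compound 2 to compound 3 (0.22 log units; within the scatter) alone did not show. Compound 4 is the only compound shown with chlorine on this ring, and its change also removes the nitrile and both methyl groups of compound 3, so these parts cannot be separated.

As far as these compounds go, whether a plain phenyl, a bromophenyl or an aminophenyl group in this place would follow compound 4 or compound 3 remains open. Nothing in the data at hand accounts for the lower number of compound 4.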